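Swapping the aryl group on a dichlorinated lactone core

A few compounds are considered here, and "the series" means these few. Any claim that something is new, unique, unknown or untested is made for them only; others in the source may bear on it.

Compound 1 `O=C1C[C@H](O)C[C@@H](/C=C/c2c(Cl)cc(Cl)cc2-c2ccc(Cl)c(Cl)c2)O1` — 25 nM
Compound 2 `Cc1ccc(C)c(-c2ccc(Cl)c(Cl)c2)c1/C=C/[C@@H]1C[C@@H](O)CC(=O)O1` — 13 nM
Compound 3 `Cc1cc(C)c(/C=C/[C@@H]2C[C@@H](O)CC(=O)O2)c(-c2ccc(F)cc2)c1` — 13 nM

Of the compounds shown here, three have been measured in an assay for inhibition of 3-hydroxy-3-methylglutaryl-coenzyme A reductase (Rattus norvegicus) (on this read-out lower numbers stand for stronger inhibition and higher numbers for weaker inhibition), each carrying the same lactone core joined through a vinyl linker to a biaryl. Compound 1 gives 25 nM in this assay, the highest number of the three, but its gaps to compound 2 and to compound 3 lie within the scatter, so the three cannot be ranked against each other. Compound 2 bears the same 3,4-dichlorophenyl as compound 1 on a dimethyl core. In this assay compound 2 gives 13 nM. Compound 3 bears a fluorophenyl on a dimethyl core and gives 13 nM.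

Compound 4 `Cc1cc(-c2cc(Cl)cc(Cl)c2/C=C/[C@@H]2C[C@@H](O)CC(=O)O2)ccc1F` has not yet been measured. It differs from compound 1 in one place: 4-fluoro-3-methylphenyl in place of 3,4-dichlorophenyl on an aromatic carbon. The new group sits ortho to a large group and meta to two chloro groups on the dichlorinated core of compound 1.

Since compound 3, with a fluorophenyl in place of a dichlorophenyl, gives 13 nM, close to compound 2 with 13 nM, the step is expected to be small, a 1.4-fold lower number from compound 1 to compound 4 (0.14 log units; within the scatter), with no change beyond the scatter. Compound 4 is therefore estimated at 18 nM, within a range of 7 nM to 45 nM.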

Compound 4, half-maximal inhibitory concentration: 29 nM
Compound 4: the middle estimate sits 1.6-fold (0.21 log units) below what was measured; low and high end bracket the measured number.
By their numbers in this assay, from the lowest: compounds 2, 3, 1 and 4 (each within the scatter of the next, the first and the last beyond it).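

For the compounds shown here, the exchange of 3,4-dichlorophenyl for 4-fluoro-3-methylphenyl, on an aromatic carbon ortho to a large group and meta to two chloro groups, is the first change in this set that can be read in one place, and in this assay it amounts to a 1.2-fold higher number from compound 1 to compound 4 (0.06 log units; within the scatter). On the dichlorinated core of compound 1, this position therefore accepts the second substituted phenyl group with no change beyond the scatter, so the two groups cannot be told apart on this read-out. No measurement at hand bears on why the two groups read alike.

The other steps among these compounds cannot be read, so it remains open whether the same exchange would also leave the number unchanged on a dimethyl core like those of compound 2 and compound 3. From the compounds shown here alone, it is also open whether a phenyl group carrying an amine or a carboxylic acid at this position would shift the number beyond the scatter, and so whether this position accepts groups of a different kind.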